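This account rests on a few compounds, and the source may have more. Where it says the series, first, only, none or still open, it means among the compounds named here.

In a functional assay on MOLT-4 cells (Homo sapiens) for inhibition, read by MTT assay, with a stated time of 48 h (on this read-out higher numbers stand for weaker inhibition and lower numbers for stronger inhibition), compound 1 `O=C(/C=C/c1cc(C(=O)c2ccccc2F)c[nH]1)CC(=O)C(=O)O` gives 20000 nM. Compound 2 `O=C(/C=C/c1cc(C(=O)c2cccc(F)c2)c[nH]1)CC(=O)C(=O)O` reads > 40000 nM, which is a limit and not a number. Within the data shown here, the only measured step is an at least 2.0-fold higher number from compound 1 to compound 2 (0.30 log units; that floor lies within the scatter), a floor that stays within the scatter and so gives no firm size. Compound 3 `N#Cc1ccc(C(=O)c2c[nH]c(/C=C/C(=O)CC(=O)C(=O)O)c2)cc1` differs from compound 2 as follows: 4-cyanophenyl in place of 3-fluorophenyl on a carbonyl carbon. With so little guidance, no step beyond the scatter is expected in this assay. The expected step is an at least 1.1-fold lower number from compound 2 to compound 3 (0.05 log units; that floor lies within the scatter). For compound 3 the estimate is 35000 nM, with an expected range of 12000 nM to 80000 nM.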

Compound 3, half-maximal inhibitory concentration: > 40000 nM
Compound 3 ended at the assay's limit; the forecaster's own chance of this, stated with the estimate: 50%; middle value at least 1.1-fold (0.05 log units) away from the limit.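

In this assay compound 3 reads > 40000 nM, which is a limit and not a number. A second group on this carbonyl carbon, 4-cyanophenyl, now gives no number, and its change from 2-fluorophenyl gives an at least 2.0-fold higher number from compound 1 to compound 3 (0.30 log units; that floor lies within the scatter), so no firm size follows. The series now gathers at one limit: the limit of > 40000 nM in this assay, at which 2 of the 3 values shown sit.

The step between the two limits cannot be read. Open, as far as these compounds go, is whether 2-chlorophenyl or an amine on this carbonyl carbon would give a number in this assay, and so whether this position can separate compounds at all.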